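The compounds below may be only part of what the source reports. "The series", "measured", "known", "first", "only" and "open" are said of these compounds alone.

The series shares one core, varied only in the group attached to the carbonyl carbon of the amide. Compound 1 `Nc1ccc(C(=O)Nc2nc(-c3ccccc3)nc3c2nnn3Cc2ccccc2)cc1` gives 7.1 nM in an assay (strain Wistar) for displacement of a labelled ligand from adenosine receptor A1 (Rattus norvegicus), read by scintillation counting; a higher number here means a weaker inhibitor, a lower number a stronger inhibitor. Compound 2 `O=C(Nc1nc(-c2ccccc2)nc2c1nnn2Cc1ccccc1)c1ccoc1` gives 10 nM in this assay, and compound 3 `O=C(Nc1nc(-c2ccccc2)nc2c1nnn2Cc1ccccc1)c1cccc(F)c1` gives 22 nM. Compound 3 stands highest of the three numbers: the step of a 3.1-fold higher number from compound 1 to compound 3 (0.49 log units; beyond the scatter) and the step of a 2.2-fold higher number from compound 2 to compound 3 (0.34 log units; beyond the scatter) both lie beyond the scatter, whereas the step of a 1.4-fold higher number from compound 1 to compound 2 (0.15 log units; within the scatter) does not. Compound 4 `O=C(Nc1nc(-c2ccccc2)nc2c1nnn2Cc1ccccc1)c1ccccc1F` differs from compound 3 in that (2-fluorophenyl in place of 3-fluorophenyl on a carbonyl carbon). Among the measured compounds shown here, no measured step moves a substituent to another place on the same ring; the measured steps exchange one carbonyl substituent for a different one, and all of them stay modest in size, so a step of that order, or none beyond the scatter, is the working expectation here. For compound 4 the estimate in this assay is 22 nM, with a range from 8 nM to 60 nM. The step of no change at the digits printed from compound 3 to compound 4 (within the scatter) is accordingly expected to be small.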

Compound 4, inhibition constant: 40 nM
Beside the measured number, compound 4's estimate is 1.8-fold (0.26 log units) below it; the measured number falls inside the stated range.
By their numbers in this assay, from the lowest: compounds 1 and 2 (each within the scatter of the next); then compounds 3 and 4 (each within the scatter of the next).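

Here 2-fluorophenyl in place of 3-fluorophenyl is the first measured step that moves a substituent around the same ring, and in this assay a 1.8-fold higher number from compound 3 to compound 4 (0.26 log units; within the scatter) does not separate the two fluorophenyl compounds. Both remaining steps, a 4.0-fold higher number from compound 2 to compound 4 (0.60 log units; beyond the scatter) and a 5.6-fold higher number from compound 1 to compound 4 (0.75 log units; beyond the scatter), lie beyond the scatter, so compound 4 joins compound 3 in a fluorophenyl pair standing apart from the furan-3-yl and 4-aminophenyl compounds, with the larger of these steps still modest. Nothing available bears on why these steps take the sizes they do.

Open, as far as these compounds go, is how an unsubstituted phenyl or a cyclohexyl on this carbonyl carbon would compare with the fluorophenyl pair. Also open, from the compounds shown here alone, is whether these steps would hold with the phenyl or benzyl groups of the shared core exchanged.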